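The compounds below may be only part of what the source reports. "The series", "measured", "known", "first", "only" and "open" are said of these compounds alone.

Compounds measured so far in an ADME assay on Vero cells (Chlorocebus sabaeus) for cytotoxicity, read by fluorescence and resazurin assay, with a stated time of 3 days; a higher number here means that more compound is tolerated, a lower number that less compound is tolerated:
compound 1, `CC(=O)C[C@H]1O[C@@H](On2cc(CN3C(=O)/C(=N\Nc4ccccc4)c4ccccc43)nn2)[C@H](OC(C)=O)[C@@H](OC(C)=O)[C@@H]1OC(C)=O`, gives 108000 nM
compound 2, `CC(=O)C[C@H]1O[C@@H](On2cc(CN3C(=O)/C(=N\Nc4ccc(C#N)cc4)c4ccccc43)nn2)[C@H](OC(C)=O)[C@@H](OC(C)=O)[C@@H]1OC(C)=O`, gives 75400 nM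
compound 3, `CC(=O)C[C@H]1O[C@@H](On2cc(CN3C(=O)/C(=N\Nc4ccccc4)c4ccccc43)nn2)[C@H](OC(C)=O)[C@@H](OC(C)=O)[C@H]1OC(C)=O`, gives 65200 nM

Compound 3 has the lowest of the three numbers, but both neighbours sit within the scatter of it; the step of a 1.7-fold lower number from compound 1 to compound 3 (0.22 log units; within the scatter) rests on (the fact that compounds 1 and 3 differ only in the configuration as drawn). Compound 4, `CC(=O)C[C@H]1O[C@@H](On2cc(CN3C(=O)/C(=N\Nc4ccc(F)cc4)c4ccccc43)nn2)[C@H](OC(C)=O)[C@@H](OC(C)=O)[C@H]1OC(C)=O`, differs from compound 3 by fluoro in place of hydrogen on an aromatic carbon. Within the data shown here, the only measured step of the same kind, a substituent entering on an aromatic carbon, is a 1.4-fold lower number from compound 1 to compound 2 (0.16 log units; within the scatter). A change of similar size is expected here, so the estimated step of a 1.2-fold lower number from compound 3 to compound 4 (0.07 log units; within the scatter) should not pass beyond the scatter. Compound 4 is therefore expected to give about 55000 nM in this assay, within a range from 25000 nM to 120000 nM.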

Compound 4, half-maximal cytotoxic concentration: 78600 nM
For compound 4 the middle estimate is 1.4-fold (0.16 log units) below the measured one; measured number inside the range.
By their numbers in this assay, from the lowest: compounds 3, 2, 4 and 1 (each within the scatter of the next).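

In this assay the step of a 1.2-fold higher number from compound 3 to compound 4 (0.08 log units; within the scatter) shows that fluoro in place of hydrogen on this aromatic carbon, para to a large group, leaves the number within the scatter. Earlier, the only substituent here was the cyano of compound 2, on the other drawn configuration; compound 4 gives a second substituent, on the configuration of compound 3, and again the step stays within the scatter. Nothing at hand accounts for this step.

As far as these compounds go, how an amine or a carboxylic acid at this position would read stays open. So does whether fluoro reads alike on the configuration of compound 1.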